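The compounds below may be only part of what the source reports. "The series", "measured", "known", "first", "only" and "open" are said of these compounds alone.

Of the compounds shown here, three from one series have been tested in an assay on CHO cells for displacement of a labelled ligand from Alpha-2C adrenergic receptor (Homo sapiens); on this read-out higher numbers stand for weaker inhibition and lower numbers for stronger inhibition. Compound 1 `CC(Oc1ccccc1-c1ccc([N+](=O)[O-])cc1)C1=NCCN1` gives 302 nM. Compound 2 `CC(Oc1ccccc1-c1ccncc1)C1=NCCN1` gives 1450 nM, and compound 3 `CC(Oc1ccccc1-c1ccccc1)C1=NCCO1` gives 5890 nM. Among these three numbers compound 2 stands second highest: compound 3 lies higher by a gap beyond the scatter, and compound 1 lies lower by a gap beyond the scatter.

The next compound, compound 4 `Cc1cccc(-c2ccccc2OC(C)C2=NCCN2)c1`, has not yet been measured. It differs from compound 2 in one place, (3-methylphenyl in place of pyridin-4-yl on an aromatic carbon). Among the compounds with values here, no measured pair shows this exact change, so the step can only be guessed. The step from compound 2 to compound 4 is expected to be a 2.1-fold lower number from compound 2 to compound 4 (0.32 log units; beyond the scatter), a modest move toward a lower number. For compound 4 the expected value is 700 nM, within a range from 200 nM to 2500 nM.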

Compound 4, inhibition constant: 245 nM
Estimate against measurement, compound 4: 2.9-fold (0.46 log units) above, within the range that was stated.
By their numbers in this assay, from the lowest: compounds 4 and 1 (each within the scatter of the next); then compound 2; then compound 3.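

At this position, on an aromatic carbon ortho to a group of 8 heavy atoms, the choice of ring matters: 3-methylphenyl in place of pyridin-4-yl gives a 5.9-fold lower number from compound 2 to compound 4 (0.77 log units; beyond the scatter) in this assay, a step beyond the scatter. Within the data shown here, this is the first single-place step, and it swaps a ring with one hetero atom for a ring of carbon only that carries a methyl. No measurement at hand explains the shift. From the compounds shown here alone, whether the step comes from losing the ring nitrogen or from gaining the methyl stays open. So does how a 3-methoxyphenyl or 3-aminophenyl group would behave at this place on the same core.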